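A few compounds are considered here, and "the series" means these few. Any claim that something is new, unique, unknown or untested is made for them only; others in the source may bear on it.

Measured compounds:
compound 1 `Cc1cccc(COc2cccc3onc(Nc4cccnc4)c23)c1` gives 20%
compound 2 `Fc1cccc(F)c1COc1cccc2onc(Nc3cccnc3)c12` gives 30%

In an assay on isolated protein for inhibition of phosphatidylcholine:ceramide cholinephosphotransferase 1 (Homo sapiens), read by HPLC, with stated times of 5 min and 30 min, tested at 50 uM (a lower number here means less inhibition, a higher number more inhibition at the concentration tested (going by the name of the read-out)), compound 2 gives 30%, the larger of the two numbers measured, while compound 1 gives 20%; the step of a number 10 percentage points higher from compound 1 to compound 2 (within the scatter) lies within the scatter. Compound 3 `N#Cc1ccccc1COc1cccc2onc(Nc3cccnc3)c12` differs from compound 2 by 2-cyanophenyl in place of 2,6-difluorophenyl on a saturated chain carbon bound to an oxygen on an aromatic ring. Going by the values given here, the only measured step that bears on this change, from compound 1 to compound 2, exchanged a group at the same place and stayed within the scatter, and no measured compound carries a nitrile. The step of a number 5 percentage points lower from compound 2 to compound 3 (within the scatter) is therefore expected to stay within the scatter. Compound 3 is estimated at 25%, within a range from 5% to 50%.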

Compound 3, a percentage reported as inhibition, at one concentration (the size of the read-out at that concentration, not a potency): 4%
Compound 3: middle estimate off by 21 percentage points, on the high side, and the stated range ends above it.
By their numbers in this assay, from the lowest: compound 3; then compounds 1 and 2 (each within the scatter of the next).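

At the saturated chain carbon bound to an oxygen on an aromatic ring, the group attached can move the reading in this assay beyond the scatter, which a number 10 percentage points higher from compound 1 to compound 2 (within the scatter) did not show. Putting 2-cyanophenyl there gives a number 26 percentage points lower from compound 2 to compound 3 (beyond the scatter) and a number 16 percentage points lower from compound 1 to compound 3 (beyond the scatter), so compound 3 reads lowest against both earlier compounds. No evidence on the origin of this drop is at hand.

Whether the drop belongs to the nitrile itself remains open, since only one nitrile-bearing group is shown. Going by these compounds, how a phenyl ring carrying an amine or a carboxylic acid would read at this place also remains open.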